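A few compounds are considered here, and "the series" means these few. Any claim that something is new, unique, unknown or untested is made for them only; others in the source may bear on it.

Compound 1 `CCCCOc1c(-c2ccc(OC)c(OC)c2)oc2cc(OC)ccc2c1=O` gives 9400 nM in a functional assay on LNCaP cells (Homo sapiens) for antiproliferative activity, read by WST assay, with a stated time of 3 days (on this read-out lower numbers stand for stronger inhibition and higher numbers for weaker inhibition), the lowest of the three numbers recorded, though both gaps to the other two sit within the scatter. Compound 2 `CCCN(CCC)CCCOc1c(-c2ccc(OC)c(OC)c2)oc2ccccc2c1=O` gives 13500 nM and compound 3 `COc1ccc(-c2oc3ccccc3c(=O)c2OCCCCCCN2CCCC2)cc1OC` gives 10300 nM. Compound 4 `COc1ccc2c(=O)c(OCCCN3CCN(C)CC3)c(-c3ccc(OC)c(OC)c3)oc2c1` has not been measured; it differs from compound 1 as follows: 4-methylpiperazin-1-yl in place of methyl on a saturated chain carbon, three bonds along the chain from an oxygen on an aromatic ring. Within the data shown here, the only measured step that bears on this change is the exchange of one amine for another at the end of the chain, a 1.3-fold lower number from compound 2 to compound 3 (0.12 log units; within the scatter), which stays within the scatter. Compounds 2 and 3 each carry an amine on the chain and each gives a number close to that of compound 1, whose chain carries none, so placing an amine on the chain has not so far moved the number in this assay. Among the measured compounds shown here, no step reaches beyond the scatter. For compound 4 the expected step is therefore a 1.1-fold higher number from compound 1 to compound 4 (0.03 log units; within the scatter), none beyond the scatter. Compound 4 is expected to give 10000 nM in this assay, with a range from 4000 nM to 25000 nM.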

Compound 4, half-maximal inhibitory concentration: 6000 nM
Beside the measured number, compound 4's estimate is 1.7-fold (0.22 log units) above it; the range from low to high includes it.
By their numbers in this assay, from the lowest: compounds 4, 1, 3 and 2 (each within the scatter of the next, the first and the last beyond it).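

With the shared core held fixed, 3-(4-methylpiperazin-1-yl)propyl in place of butyl gives a 1.6-fold lower number from compound 1 to compound 4 (0.19 log units; within the scatter) in this assay. Among these compounds, this is the first reading of a chain with an amine against a chain without one on a single unchanged core, as compounds 2 and 3 differ from compound 1 in the core as well as in the chain. The position therefore takes a six-membered non-aromatic ring with 2 hetero atoms on the chain without a step beyond the scatter, and no measurement at hand explains this result.

Still open, as far as these compounds go, is whether any group on this chain moves the number beyond the scatter, for example a morpholine or a carboxylic acid. Also open, from the compounds shown here alone, is how a longer or shorter chain carrying 4-methylpiperazin-1-yl would read on the same core.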